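This account rests on a few compounds, and the source may have more. Where it says the series, first, only, none or still open, it means among the compounds named here.

Compound 1 `O=[N+]([O-])c1ccc(-c2nnc(-c3cccnc3)n2Nc2nc3ccc(F)cc3s2)cc1`: in an ADME assay on MT4 cells (Homo sapiens) for cytotoxicity, read by MTT assay, with a stated time of 5 days (a lower number here means that less compound is tolerated, a higher number that more compound is tolerated), compound 1 gives >= 108 ug/mL, a limit of the assay rather than a number.
Compound 2 `O=[N+]([O-])c1ccc(-c2nnc(-c3cccnc3)n2Nc2nc3ccc(Br)cc3s2)cc1`: compound 2 gives 13.2 ug/mL.
Compound 3 `O=[N+]([O-])c1ccc(-c2nnc(-c3cccnc3)n2Nc2nc3ccc(Cl)cc3s2)cc1`: compound 3 gives 53.7 ug/mL.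

Among the two numbers, compound 3 stands highest; its nearest neighbour is compound 2, with a 4.1-fold higher number from compound 2 to compound 3 (0.61 log units; beyond the scatter). Compound 1 sits at the limit of >= 108 ug/mL in this assay, at which 1 of the 3 values shown sits, so the step of an at least 2.0-fold lower number from compound 1 to compound 3 (0.30 log units; that floor lies within the scatter) and the step of an at least 8.1-fold lower number from compound 1 to compound 2 (0.91 log units; beyond the scatter) are known only as floors.

Compound 4 `Cc1cccc2sc(Nn3c(-c4ccc([N+](=O)[O-])cc4)nnc3-c3cccnc3)nc12` carries 4-methyl-1,3-benzothiazol-2-yl in place of 6-chloro-1,3-benzothiazol-2-yl on a nitrogen on an aromatic ring. Within the data shown here, none of the measured steps swaps a halogen for a methyl or moves the substituent to a different carbon of the ring; all three compare halogens at one place, and the two numbers there differ by a 4.1-fold higher number from compound 2 to compound 3 (0.61 log units; beyond the scatter). Among the measured compounds shown here, the change to compound 4 therefore has no direct precedent, and the expectation is that compound 4 stays near compound 3, with a step of a 1.1-fold higher number from compound 3 to compound 4 (0.05 log units; within the scatter) expected, not clearly beyond the scatter. Compound 4 is estimated at 60 ug/mL, in a range from 25 ug/mL to 120 ug/mL.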

Compound 4, half-maximal cytotoxic concentration: 13.5 ug/mL
Beside the measured number, compound 4's estimate is 4.4-fold (0.65 log units) above it; the measured number lies below the stated range.
By their numbers in this assay, from the lowest: compounds 2 and 4 (each within the scatter of the next); then compound 3. At a limit, above all of these: compound 1.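

Replacing 6-chloro-1,3-benzothiazol-2-yl with 4-methyl-1,3-benzothiazol-2-yl on this nitrogen matters in this assay, giving a 4.0-fold lower number from compound 3 to compound 4 (0.60 log units; beyond the scatter), so the number here responds to more than a swap of one halogen for another. Against the 6-bromo-1,3-benzothiazol-2-yl group the same kind of change gives a 1.0-fold higher number from compound 2 to compound 4 (0.01 log units; within the scatter), which shows that a group without any halogen can read like the bromo compound. Against the 6-fluoro-1,3-benzothiazol-2-yl group the step is an at least 8.0-fold lower number from compound 1 to compound 4 (0.90 log units; beyond the scatter), and it is known only as a floor: the limit of >= 108 ug/mL in this assay, at which 1 of the 4 values shown sits.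

Compound 4 changes both the substituent and the carbon that carries it, so the compounds shown cannot separate the contribution of the methyl from that of its location. They also leave open how an amine, a methoxy group or a carboxylic acid on that ring would read.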